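The source may report more compounds than this note shows. Statements on the series, on what has been measured and on what is new or still open speak of the compounds shown alone.

In an ADME assay on MT4 cells (Homo sapiens) for activation, read by MTT assay (a lower number here means that less compound is tolerated, a higher number that more compound is tolerated), compound 2 `CCCSc1nc(C(C)c2c(F)cccc2Cl)c(C)c(=O)[nH]1` gives > 1500 nM, which is a limit and not a number. Compound 1 `CCCCSc1nc(C(C)c2c(F)cccc2Cl)cc(=O)[nH]1` gives > 73000 nM, also a limit and not a number. With only these two limits in hand, compound 2 has no exact place in the series, and the two compounds cannot be put in order.

Compound 3 `CCCCSc1nc(C(C)c2c(F)cccc2Cl)c(C)c(=O)[nH]1` differs from compound 2 by methyl in place of hydrogen on a saturated chain carbon, three bonds along the chain from a sulfur. The same difference reads as propyl to butyl. Compound 1 carries the butyl chain as well, and its limit of > 73000 nM is the main support for expecting compound 3 to be well tolerated. Among the compounds with values here, no measured step in this assay shows the effect of this change, so the size of the step is only a rough expectation. The expected step is upward, a step that the limit leaves unreadable from compound 2 to compound 3, and it is counted from a limit. For compound 3 the estimated value is 30000 nM, with an expected range of 4000 nM to 150000 nM.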

Compound 3, half-maximal cytotoxic concentration: > 1500 nM
Compound 3: a limit, no number; the forecaster's own chance of this, stated with the estimate: 60%; the middle value does not contradict the limit.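

In this assay compound 3 gives > 1500 nM, which is a limit and not a number. Within the data shown here, with compound 1 and compound 2 also standing as limits, no step to compound 3 can be read from either of them. The compounds shown leave open how far propyl to butyl, or methyl in place of hydrogen on an aromatic carbon, shifts the tolerated concentration.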